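A New Phenyl Group in a Flat Series

The compounds below may be only part of what the source reports. "The series", "measured", "known", "first", "only" and "open" are said of these compounds alone.

Of the compounds shown here, three sharing one core have been tested so far: compound 1 `CCC1=C(O)c2c(oc(-c3ccc(C)cc3)cc2=O)C(CC)(CC)C1=O`, compound 2 `CCC1=C(O)c2c(oc(-c3ccc(CC)cc3)cc2=O)C(CC)(CC)C1=O` and compound 3 `CCC1=C(O)c2c(oc(-c3ccc(OC)c(Cl)c3)cc2=O)C(CC)(CC)C1=O`. In a functional assay on KB cells (Homo sapiens) for antiproliferative activity, read by sulforhodamine B assay, with a stated time of 3 days (on this read-out higher numbers stand for an effect only at larger amounts of compound and lower numbers for an effect already at smaller amounts), compound 1 gives 39.2 uM, compound 2 gives 21.9 uM and compound 3 gives 24.9 uM. Compound 3 therefore stands with the other two, nearest to compound 2, and no gap among the three goes beyond the usual scatter.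

The next compound, compound 4 `CCC1=C(O)c2c(oc(-c3cc(C)c(O)c(C)c3)cc2=O)C(CC)(CC)C1=O`, replaces the 3-chloro-4-methoxyphenyl group of compound 3 with 4-hydroxy-3,5-dimethylphenyl, on an aromatic carbon next to the ring oxygen: 4-hydroxy-3,5-dimethylphenyl in place of 3-chloro-4-methoxyphenyl on an aromatic carbon.

Two measured steps changed the group at this same place: a 1.6-fold lower number from compound 1 to compound 3 (0.20 log units; within the scatter) and a 1.1-fold higher number from compound 2 to compound 3 (0.06 log units; within the scatter). A third, a 1.8-fold lower number from compound 1 to compound 2 (0.25 log units; within the scatter), made a smaller change to the group there. All three lie within the scatter, so the series offers no sign yet of a large effect at this place. However, no tested compound carries a hydroxy on this group, which leaves the estimate uncertain.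

The expected result in this assay is a 1.1-fold lower number from compound 3 to compound 4 (0.05 log units; within the scatter), with no change beyond the scatter. For compound 4 the estimated value is 22 uM, with an expected range from 9 uM to 50 uM.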

Compound 4, concentration for half-maximal effect: 18.3 uM
The estimate for compound 4 lay 1.2-fold (0.08 log units) above the measured number; the range from low to high includes it.
By their numbers in this assay, from the lowest: compounds 4, 2, 3 and 1 (each within the scatter of the next, the first and the last beyond it).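

In this assay, among the compounds shown here, the 4-hydroxy-3,5-dimethylphenyl group brings a hydroxy to this position for the first time, with 1 hydrogen-bond donor where the 3-chloro-4-methoxyphenyl group has 0, yet a 1.4-fold lower number from compound 3 to compound 4 (0.13 log units; within the scatter) stays within the scatter, as does a 1.2-fold lower number from compound 2 to compound 4 (0.08 log units; within the scatter). The series now also has its first step beyond the scatter, though only a modest one: a 2.1-fold lower number from compound 1 to compound 4 (0.33 log units; beyond the scatter). This shows that a change at this position can move the number slightly, but only the two ends of the series are separated, and compound 2 and compound 3 remain within the scatter of both; no evidence is available to explain any of these differences.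

As far as these compounds go, compound 4 differs from the other compounds in both its hydroxy and its two methyl groups, so the contribution of each remains open, and a plain 4-hydroxyphenyl group would be needed to begin separating them. Also open, from the compounds shown here alone, is whether a quite different group on the phenyl ring at this position, such as an amine or a carboxylic acid, would move the number much further than any step seen here.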